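The compounds below may be only part of what the source reports. "The series", "measured", "known", "first", "only" and "open" are said of these compounds alone.

Compound 1 `NS(=O)(=O)OC[C@@H]1C[C@@H](n2nnc3c(NCc4cccs4)ncnc32)C[C@@H]1O` — 15.9 nM
Compound 2 `NS(=O)(=O)OC[C@@H]1C[C@@H](n2nnc3c(NCCCc4ccccc4)ncnc32)C[C@@H]1O` — 149 nM
Compound 3 `NS(=O)(=O)OC[C@@H]1C[C@@H](n2nnc3c(NC4CCCC4)ncnc32)C[C@@H]1O` — > 10000 nM

In an assay on a protein complex for inhibition of NEDD8 activating enzyme (Homo sapiens), read by HTRF, with a stated time of 2 h, in the presence of a further agent that is not named here (on this read-out lower numbers stand for stronger inhibition and higher numbers for weaker inhibition), compound 1 gives 15.9 nM and compound 2 gives 149 nM. For compound 3 the assay reports only a limit, > 10000 nM, so compound 3 stands at the weak end of the three. Compound 4 `NS(=O)(=O)OC[C@@H]1C[C@@H](n2nnc3c(N[C@@H]4c5ccccc5C[C@@H]4O)ncnc32)C[C@@H]1O` differs from compound 3 by a group of 10 heavy atoms (9 carbon, 1 oxygen; one five-membered non-aromatic ring of carbon only, one six-membered aromatic ring of carbon only) in place of a group of 5 heavy atoms (5 carbon; one five-membered non-aromatic ring of carbon only), on a nitrogen on an aromatic ring. Among the measured compounds shown here, two measured steps bear on this change: an at least 620-fold higher number from compound 1 to compound 3 (2.79 log units; beyond the scatter) and an at least 67-fold higher number from compound 2 to compound 3 (1.82 log units; beyond the scatter), both large losses when a group carrying an aromatic ring was swapped for cyclopentyl. Compound 4 runs that exchange in reverse, bringing an aromatic ring back onto the nitrogen, so a large fall in the number is expected, about an at least 500-fold lower number from compound 3 to compound 4 (2.69 log units; beyond the scatter). Compound 4 is therefore estimated at 20 nM, with a likely range from 3 nM to 300 nM.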

Compound 4, half-maximal inhibitory concentration: 2.28 nM
Compound 4: the middle estimate sits 8.8-fold (0.94 log units) above what was measured; measured number below the stated range.
By their numbers in this assay, from the lowest: compound 4; then compound 1; then compound 2. At a limit, above all of these: compound 3.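

Compound 3 is known only as a limit, so the first step below gives a minimum size: the limit of > 10000 nM in this assay, at which 1 of the 4 values shown sits.

On the nitrogen on an aromatic ring, the five-membered non-aromatic ring of carbon no longer goes with weak inhibition once an aromatic ring and an oxygen come with it, giving an at least 4300-fold lower number from compound 3 to compound 4 (3.64 log units; beyond the scatter). This new group also surpasses both earlier aromatic groups, with a 65-fold lower number from compound 2 to compound 4 (1.82 log units; beyond the scatter) and a 7.0-fold lower number from compound 1 to compound 4 (0.84 log units; beyond the scatter).

Going by these compounds, whether the gain follows the oxygen or the aromatic ring stays open, as does the part played by the two defined stereocentres. A hydroxycyclopentyl group and an oxygen-free indanyl group would tell these apart.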